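The source may hold more compounds than are shown below. What is called first, only, known or untested is meant among the compounds shown, and "the series" means these compounds.

Compound 3 `CCc1ccc(C(=O)NN(C(=O)c2ccccc2)C(C)(C)C)cc1` gives 4.9 nM. Compound 1 `CC(C)(C)N(NC(=O)c1ccccc1)C(=O)c1ccccc1Cl` gives 75.9 nM. Compound 2 `Cc1ccc(C(=O)NN(C(=O)c2ccccc2Cl)C(C)(C)C)cc1C` gives 87.1 nM.

In an assay on cells for agonist activity at ecdysone receptor (Bombyx mori), read by a luciferase reporter, with a stated time of 24 h (a higher number here means that more compound is needed for the effect, a lower number that less compound is needed), compound 3 stands with the lowest number of the three; compound 1 is nearest and compound 2 furthest, both beyond the scatter. Compound 4 `CCc1ccc(C(=O)NN(C(=O)C2CC=CCC2)C(C)(C)C)cc1` differs from compound 3 by cyclohex-3-en-1-yl in place of phenyl on a carbonyl carbon. Among the measured compounds shown here, the only measured step, a 1.1-fold higher number from compound 1 to compound 2 (0.06 log units; within the scatter), changed the other carbonyl-bound ring and stayed within the scatter, so it does not bear on this change. Nothing measured here shows what swapping an aromatic ring for a non-aromatic one on this carbonyl does, so the expectation rests on no direct evidence. An increase in the number is expected, a 10-fold higher number from compound 3 to compound 4 (1.01 log units; beyond the scatter), with compound 4 estimated at 50 nM in a range from 8 nM to 300 nM.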

Compound 4, half-maximal effective concentration: 1000 nM
Compound 4: the middle estimate sits 20-fold (1.30 log units) below what was measured, and the stated range ends below it.
By their numbers in this assay, from the lowest: compound 3; then compounds 1 and 2 (each within the scatter of the next); then compound 4.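

In this assay replacing phenyl with cyclohex-3-en-1-yl on this carbonyl carbon gives a 200-fold higher number from compound 3 to compound 4 (2.31 log units; beyond the scatter) and so shows that this position is highly sensitive to the ring it carries. This holds even though both rings have the same count of heavy atoms and differ in being aromatic or non-aromatic. Nothing available explains the size of this step.

As far as these compounds go, whether any non-aromatic ring would behave the same remains open. A saturated cyclohexyl, a pyridine or a thiophene on the same carbonyl would help separate these possibilities.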